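This account rests on a few compounds, and the source may have more. Where it says the series, first, only, none or still open, it means among the compounds named here.

Working notes on the series. Three measured analogues share one core and differ only in the aryl group attached to the carbonyl carbon. Compound 1 `COc1cc(-c2nnc3n2NC(c2ccco2)C(C(=O)c2cccc(Br)c2)S3)cc(OC)c1OC` gives 36900 nM in a functional assay on A549 cells (Homo sapiens) for cytotoxicity, read by MTT assay, with a stated time of 48 h; on this read-out lower numbers stand for stronger inhibition and higher numbers for weaker inhibition. Compound 2 `COc1cc(-c2nnc3n2NC(c2ccco2)C(C(=O)c2cccs2)S3)cc(OC)c1OC` gives 78700 nM in this assay, a step of a 2.1-fold higher number from compound 1 to compound 2 (0.33 log units; beyond the scatter). Compound 3 `COc1cc(-c2nnc3n2NC(c2ccco2)C(C(=O)c2ccc(C(F)(F)F)cc2)S3)cc(OC)c1OC` gives 37200 nM in this assay, with steps of a 1.0-fold higher number from compound 1 to compound 3 (0.00 log units; within the scatter) and a 2.1-fold lower number from compound 2 to compound 3 (0.33 log units; beyond the scatter). Compound 3 therefore stands second highest of the three numbers, indistinguishable from compound 1 and apart from compound 2 only by a modest margin.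

Compound 4 `COc1cc(-c2nnc3n2NC(c2ccco2)C(C(=O)c2ccccc2)S3)cc(OC)c1OC` follows from compound 3 by hydrogen in place of trifluoromethyl on an aromatic carbon. For the measured compounds named here, no measured pair removes a substituent from this six-membered ring, so the steps that bear on the change are the exchanges of the whole aryl group: a flat a 1.0-fold higher number from compound 1 to compound 3 (0.00 log units; within the scatter) and a modest 2.1-fold higher number from compound 1 to compound 2 (0.33 log units; beyond the scatter). Two substituted phenyl groups gave the same number, and only the five-membered heteroaryl moved it. On this basis a step of a 1.2-fold higher number from compound 3 to compound 4 (0.08 log units; within the scatter) is expected in this assay, small and likely within the scatter, with a slight lean toward a higher number. Compound 4 is accordingly estimated at 45000 nM in this assay, within a range from 20000 nM to 100000 nM.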

Compound 4, half-maximal inhibitory concentration: 33400 nM
Estimate against measurement, compound 4: 1.3-fold (0.13 log units) above; low and high end bracket the measured number.
By their numbers in this assay, from the lowest: compounds 4, 1 and 3 (each within the scatter of the next); then compound 2.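

Taking the substituent off the six-membered ring altogether does not separate the compounds in this assay: the trifluoromethyl group gives way to hydrogen with a 1.1-fold lower number from compound 3 to compound 4 (0.05 log units; within the scatter), and the bromo group with a 1.1-fold lower number from compound 1 to compound 4 (0.04 log units; within the scatter). The earlier compounds shown here compared only substituted phenyl groups, whereas these steps show that plain phenyl also sits with them, so neither substituent is set apart from hydrogen on this read-out. For the compounds shown here, the exchange of the thiophen-2-yl group for phenyl gives a 2.4-fold lower number from compound 2 to compound 4 (0.37 log units; beyond the scatter), which leaves compound 2 as the only compound beyond the scatter of the others, with the highest number of the four, and no measurement of any other kind is available to account for the pattern.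

Whether a group of another kind on this ring, such as an amine or a carboxylic acid, would move the number remains open, since the only substituents shown are trifluoromethyl and bromo. The rest of the shared core is the same in all four compounds, so they say nothing about how changes there would read in this assay.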